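From chloro to methyl on compound 3

This account rests on a few compounds, and the source may have more. Where it says the series, first, only, none or still open, it means among the compounds named here.

For the measured compounds named here, in a functional assay on thoracic aorta (Rattus norvegicus, strain Wistar), with a stated time of 15 min (a lower number here means that less compound is needed, a higher number that more compound is needed for the effect), compound 3 `CCOc1ccc(Br)cc1C(C)NC(=O)NS(=O)(=O)c1ccc(Cl)cc1` gives 171000 nM, the higher of the two exact numbers so far. Compound 2 `CCOc1ccc(Br)cc1C(C)NC(=O)N(C)S(=O)(=O)c1ccc(C)cc1` gives 28600 nM, a lower number, and the gap between them lies beyond the usual scatter. Compound 1 `CCOc1ccc(Cl)cc1C(C)NC(=O)NS(=O)(=O)c1ccc(C)cc1` gives > 300000 nM, which is a limit and not an exact number.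

Compound 4 `CCOc1ccc(Br)cc1C(C)NC(=O)NS(=O)(=O)c1ccc(C)cc1` has not yet been measured. It carries methyl in place of chloro on an aromatic carbon, para to a large group, so 4-chlorophenyl becomes 4-methylphenyl (methyl in place of chloro on an aromatic carbon). Going by the values given here, no measured pair shows this change on its own. Compound 1 and compound 2 both carry 4-methylphenyl, but each differs from compound 4 elsewhere, so compound 3 remains the closest guide, at 171000 nM. The expected change is a 1.1-fold higher number from compound 3 to compound 4 (0.05 log units; within the scatter), a step estimated to stay within the scatter. The measurement could also end up as a limit. For compound 4, the estimated value is 190000 nM, with an expected range from 70000 nM to 450000 nM.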

Compound 4, half-maximal effective concentration: > 300000 nM
Compound 4: only a limit was reported (the forecaster's own chance of this, stated with the estimate: 35%); middle value at least 1.5-fold (0.19 log units) away from the limit.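

In this assay compound 4 gives only a limit, > 300000 nM. Methyl in place of chloro on the aromatic carbon gives an at least 1.7-fold higher number from compound 3 to compound 4 (0.24 log units; that floor lies within the scatter), so this swap shows no clear effect, and how far the true number lies past that floor is unknown. For the compounds shown here, the nitrogen offers the first single-place comparison with a clear result: hydrogen in place of methyl on that amide-type nitrogen gives an at least 10-fold higher number from compound 2 to compound 4 (1.02 log units; beyond the scatter), so in this pair much less compound is needed when the methyl is present.

On these data alone, the step from compound 1 to compound 4 cannot be read, so bromo against chloro stays open, as both values are limits: the limit of > 300000 nM in this assay, at which 2 of the 4 values shown sit. Also open is whether a longer chain on that nitrogen would keep the lower number of compound 2.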